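Cyclopentyl for Benzyl at the Amide Nitrogen

The source may hold more compounds than are shown below. What is called first, only, known or untested is meant among the compounds shown, and "the series" means these compounds.

In a functional assay on MOLT-4 cells (Homo sapiens) for inhibition (a higher number here means a weaker inhibitor, a lower number a stronger inhibitor), compound 3 `CCC(C)C(NC(=O)n1nnc2ccccc21)C(=O)NCc1ccccc1` gives 96000 nM, the second highest of three numbers. Compound 1 `CCC(C)C(NC(=O)n1nnc2ccccc21)C(=O)NC(c1ccccc1)c1ccccc1` gives 79000 nM and compound 2 `CCC(C)C(NC(=O)NO)C(=O)NCc1ccccc1` gives 126000 nM. Both steps reaching it stayed within the scatter: a 1.2-fold higher number from compound 1 to compound 3 (0.08 log units; within the scatter) and a 1.3-fold lower number from compound 2 to compound 3 (0.12 log units; within the scatter). Compound 4 `CCC(C)C(NC(=O)n1nnc2ccccc21)C(=O)NC1CCCC1` carries cyclopentyl in place of benzyl on an amide-type nitrogen. The step between compounds 1 and 3 bears on this, since it altered the same amide substituent without moving the number beyond the scatter; the step from compound 2 concerns the other side of the shared core and says little here. For compound 4 the expected step is a 1.1-fold higher number from compound 3 to compound 4 (0.06 log units; within the scatter), nothing beyond the scatter. Compound 4 is therefore estimated at about 110000 nM, between 50000 nM and 250000 nM.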

Compound 4, half-maximal inhibitory concentration: 94000 nM
Estimate against measurement, compound 4: 1.2-fold (0.07 log units) above; measured number inside the range.
By their numbers in this assay, from the lowest: compounds 1, 4, 3 and 2 (each within the scatter of the next).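

In this assay, cyclopentyl in place of benzyl on the amide-type nitrogen gives a 1.0-fold lower number from compound 3 to compound 4 (0.01 log units; within the scatter), so the aromatic ring of benzyl can give way to a smaller non-aromatic ring of carbon only without the number leaving the scatter. The earlier step at this position had only exchanged hydrogen for phenyl, leaving an aromatic ring on both sides. No measurement shown here explains this result. Going by these compounds, whether an amine or a carboxylic acid on this nitrogen would move the number beyond the scatter stays open, as does the effect of a longer chain.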